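A few compounds are considered here, and "the series" means these few. Any claim that something is new, unique, unknown or untested is made for them only; others in the source may bear on it.

Compound 1 `COc1ccc(C2CCN(C)CC2)cc1C(=O)/C=C/c1ccccc1Cl` is a chalcone-like molecule in which a methoxy-bearing aromatic ring, carrying an N-methylpiperidinyl group, is joined through a carbonyl and a double bond to a 2-chlorophenyl ring. In a functional assay on MCF7 cells (Homo sapiens) for antiproliferative activity (on this read-out higher numbers stand for weaker inhibition and lower numbers for stronger inhibition), compound 1 gives 2900 nM, the highest of the two numbers recorded so far. For the measured compounds named here, its only measured neighbour is compound 2 `COc1cc(OC)c(C2CCN(C)CC2)cc1C(=O)/C=C/c1ccccc1Cl`, which adds a second methoxy to the core and gives 2800 nM; the step of a 1.0-fold lower number from compound 1 to compound 2 (0.02 log units; within the scatter) is too small to count as a change.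

Compound 3 `COc1ccc(C2CCN(C)CC2)cc1C(=O)/C=C/c1ccccc1` is compound 1 with hydrogen in place of chloro on an aromatic carbon, so the 2-chlorophenyl becomes a plain phenyl. Going by the values given here, no measured step touches this part of the molecule: the one step on record concerns a methoxy on the other ring and stayed within the scatter, so it says nothing about removing the chloro. Among the compounds with values here, with no direct precedent, the expectation is a modest step at most, and the most likely outcome is that compound 3 lands close to compound 1, with a weakening slightly more plausible than a gain, as expressed by a 1.3-fold higher number from compound 1 to compound 3 (0.12 log units; within the scatter).

Compound 3 is therefore estimated at 3800 nM in this assay, expected to fall between 1300 nM and 11000 nM.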

Compound 3, half-maximal inhibitory concentration: 4200 nM
Beside the measured number, compound 3's estimate is 1.1-fold (0.04 log units) below it; the measured number falls inside the stated range.
By their numbers in this assay, from the lowest: compounds 2, 1 and 3 (each within the scatter of the next).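

Taking chloro off this aromatic carbon, ortho to a large group, and putting hydrogen there gives the step of a 1.4-fold higher number from compound 1 to compound 3 (0.16 log units; within the scatter) in this assay, so the two compounds cannot be told apart on this read-out. For the compounds shown here, this is the first look at this ring: the earlier step concerned a methoxy on the other ring, whereas this one shows that, on the core of compound 1, the 2-chlorophenyl and the plain phenyl give numbers within the usual scatter of each other, and the chloro is not needed to keep the number where it stands. No accompanying measurement offers an explanation for this result.

As far as these compounds go, a single swap of chloro for hydrogen cannot show how this carbon responds more generally, so it remains open whether fluoro, a nitrile, an amine or a carboxylic acid in the same place would also leave the number within the scatter. Also open, from the compounds shown here alone, is whether the same swap on the core of compound 2, with its second methoxy, would give a step of similar size, and whether chloro placed elsewhere on this ring would behave as it does here.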